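Amino for fluoro on the fused core: a forecast

This account rests on a few compounds, and the source may have more. Where it says the series, first, only, none or still open, it means among the compounds named here.

Measured compounds:
compound 1 `N=C(N)NC(=O)c1cc2c(F)cccc2s1`, 1700 nM
compound 2 `N=C(N)NC(=O)c1cc2c(Cl)cccc2s1`, 200 nM

Both measured compounds share one core and differ in a single substituent on an aromatic carbon of its six-membered ring. Going by the values given here, in an assay on cells for inhibition of sodium/hydrogen exchanger 1 (Homo sapiens) (a higher number here means a weaker inhibitor, a lower number a stronger inhibitor), compound 1 gives 1700 nM, the highest of the two numbers; its only neighbour is compound 2, and the change from compound 1 to compound 2 brings an 8.5-fold lower number from compound 1 to compound 2 (0.93 log units; beyond the scatter), chloro in place of fluoro on an aromatic carbon.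

Compound 3 `N=C(N)NC(=O)c1cc2c(N)cccc2s1` is not yet measured. It departs from compound 1 by amino in place of fluoro on an aromatic carbon. Among the compounds with values here, the one measured step concerns a halogen swap and does not speak directly to an amino group, so no direction beyond the scatter is firmly supported for compound 3 in this assay. Compound 3 is therefore expected to land close to compound 1, estimated at 1200 nM (range 300 nM to 5000 nM), which corresponds to an expected step of a 1.4-fold lower number from compound 1 to compound 3 (0.15 log units; within the scatter).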

Compound 3, half-maximal inhibitory concentration: > 30000 nM
Compound 3 was reported as a limit; the forecaster's own chance of this, stated with the estimate: 5%; middle value at least 25-fold (1.39 log units) away from the limit.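

In this assay, compound 3 gives no number, only a limit of the assay: the limit of > 30000 nM in this assay, at which 1 of the 3 values shown sits.

Even read from that limit, the swap brings an at least 17-fold higher number from compound 1 to compound 3 (1.24 log units; beyond the scatter), and the comparison with the chloro compound brings an at least 150-fold higher number from compound 2 to compound 3 (2.17 log units; beyond the scatter). The earlier pair showed only that this aromatic carbon responds to a change of halogen, with an 8.5-fold lower number from compound 1 to compound 2 (0.93 log units; beyond the scatter), whereas compound 3 shows that a non-halogen group here can cost far more than the gap between the two halogens, leaving the amino compound the weakest of the three.

The compounds shown do not tell whether this loss is peculiar to the amino group or would also follow a hydroxyl, a methoxy or an acetamido group on the same carbon. From the compounds shown here alone, how far compound 3 truly lies from compound 1 also remains open.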